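Pyridine-linked ring swap: thiophene to imidazole

A few compounds are considered here, and "the series" means these few. Any claim that something is new, unique, unknown or untested is made for them only; others in the source may bear on it.

Measured so far:
compound 1 `CC(C(=O)NCc1ccc(C(F)(F)F)nc1-c1ccc(F)c(Cl)c1)c1ccc(NS(C)(=O)=O)c(F)c1`: 0.2 nM
compound 2 `CC(C(=O)NCc1ccc(C(F)(F)F)nc1-c1ccsc1)c1ccc(NS(C)(=O)=O)c(F)c1`: 2 nM

For the measured compounds named here, in an assay on CHO cells for antagonist activity at transient receptor potential cation channel subfamily V member 1 (Homo sapiens), read by FLIPR (on this read-out higher numbers stand for weaker inhibition and lower numbers for stronger inhibition), compound 2 gives the higher of the two numbers available; the only neighbour is compound 1, and the step of a 10-fold higher number from compound 1 to compound 2 (1.00 log units; beyond the scatter) is the single measured change. Compound 3 `CC(C(=O)NCc1ccc(C(F)(F)F)nc1-n1ccnc1)c1ccc(NS(C)(=O)=O)c(F)c1` is not yet measured. It differs from compound 2 by 1H-imidazol-1-yl in place of thiophen-3-yl on an aromatic carbon. Going by the values given here, the one step that bears on this change is a 10-fold higher number from compound 1 to compound 2 (1.00 log units; beyond the scatter), which shows that exchanging the ring at this position moves the readout well beyond the scatter. Among the compounds with values here, no measured pair shows an imidazol-1-yl ring here, so the direction rests on that single step. The expected step is a 10-fold higher number from compound 2 to compound 3 (1.00 log units; beyond the scatter), a further loss. For compound 3 the estimate in this assay is 20 nM, with a range from 4 nM to 150 nM.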

Compound 3, inhibition constant: 36.1 nM
For compound 3 the middle estimate is 1.8-fold (0.26 log units) below the measured one, and the stated range covers the measured number.
By their numbers in this assay, from the lowest: compound 1; then compound 2; then compound 3.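

At this position next to the ring nitrogen, this assay separates two five-membered aromatic rings of equal heavy-atom count (an 18-fold higher number from compound 2 to compound 3 (1.26 log units; beyond the scatter)), so ring size and heavy-atom count alone do not set the number here. The exchange of 3-chloro-4-fluorophenyl for 1H-imidazol-1-yl gives the widest step in the series (a 180-fold higher number from compound 1 to compound 3 (2.26 log units; beyond the scatter)). No available measurement offers an explanation for either step.

On these data alone, whether the gap between thiophen-3-yl and 1H-imidazol-1-yl follows from the second ring nitrogen or from attachment through a ring nitrogen stays open. Also open, as far as these compounds go, is where an unsubstituted phenyl ring, a pyridin-3-yl ring or an open-chain amine such as dimethylamino would fall relative to these three compounds.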